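Shortening an Alkyl Chain and Cytotoxicity in Muscle Cells

The source may report more compounds than this note shows. Statements on the series, on what has been measured and on what is new or still open speak of the compounds shown alone.

Measured compounds:
Compound 1, `CCc1nc(-c2cc(C)c(OCCC(C)CCN3CCN(c4ccnc(N)c4)C3=O)c(C)c2)no1`: 15700 nM
Compound 2, `CCc1nc(-c2ccc(OCCC(C)CCN3CCN(c4ccnc(N)c4)C3=O)cc2)no1`: > 100000 nM
Compound 3, `CCCc1nc(-c2ccc(OCCC(C)CCN3CCN(c4ccnc(N)c4)C3=O)cc2)no1`: > 100000 nM

All three were tested in an ADME assay on RD cells (Homo sapiens) for cytotoxicity, read by MTT assay, with a stated time of 24 h; on this read-out lower numbers stand for higher toxicity in this test and higher numbers for lower toxicity in this test. For the measured compounds named here, compound 1 is the only one with a number, 15700 nM. For compound 2 the read-out is a limit of the assay, > 100000 nM. For compound 3 the read-out is likewise a limit, > 100000 nM. Two of the three read-outs thus sit at the limit of > 100000 nM in this assay, at which 2 of the 3 values shown sit.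

Compound 2 differs from compound 3 by hydrogen in place of methyl on a saturated chain carbon, two bonds along the chain from an aromatic carbon. The step this made was a step that the two limits leave unreadable from compound 3 to compound 2. How the core of compound 1 differs from that of compound 3 is not broken down here.

Compound 4, `Cc1nc(-c2cc(C)c(OCCC(C)CCN3CCN(c4ccnc(N)c4)C3=O)c(C)c2)no1`, is not yet measured. It differs from compound 1 by hydrogen in place of methyl on a saturated chain carbon bound to an aromatic carbon. Going by the values given here, this is the same kind of change as the one from compound 3 to compound 2, but the place differs: here the saturated chain carbon is bound to an aromatic carbon, there it is two bonds along the chain from an aromatic carbon.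

Among the compounds with values here, compound 1 gives 15700 nM in this assay, and the one measured instance of this kind of change left no readable size, so a small step is expected: a 1.4-fold higher number from compound 1 to compound 4 (0.15 log units; within the scatter). Compound 4 is therefore estimated at 22000 nM, between 8000 nM and 80000 nM.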

Compound 4, half-maximal cytotoxic concentration: 28800 nM
The estimate for compound 4 lay 1.3-fold (0.12 log units) below the measured number, within the range that was stated.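

In this assay, replacing the 5-ethyl-1,2,4-oxadiazol-3-yl group with 5-methyl-1,2,4-oxadiazol-3-yl gives a 1.8-fold higher number from compound 1 to compound 4 (0.26 log units; within the scatter), so on the core of compound 1 this change cannot be told apart from the ordinary differences between repeated measurements. The same kind of change on the other core, from compound 3 to compound 2, cannot be read, because both read-outs are limits of the assay and not numbers: the limit of > 100000 nM in this assay, at which 2 of the 4 values shown sit. For the compounds shown here, that leaves a single readable instance, on one core, so the data do not show whether the change behaves alike on both cores; they show only that it made no step beyond the scatter on the core of compound 1.

The compounds shown leave open what a much longer chain, such as octyl, would do in this place on the core of compound 1. They also leave open whether an amine or a carboxylic acid there would give a step beyond the scatter.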